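A few compounds are considered here, and "the series" means these few. Any claim that something is new, unique, unknown or untested is made for them only; others in the source may bear on it.

Measured so far:
compound 1, `Cc1n[nH]c(C)c1Oc1c(O)cc(O)c2c(=O)cc(-c3ccc(N4CCCNCC4)cc3)oc12`: 17600 nM
compound 2, `Cc1n[nH]c(C)c1Oc1c(O)cc(O)c2c(=O)cc(-c3ccc(N4CCN(C(C)C)CC4)cc3)oc12`: 16300 nM

In an assay on cells for inhibition of ubiquitin carboxyl-terminal hydrolase 8 (Homo sapiens), read by fluorescence, with a stated time of 30 min (on this read-out higher numbers stand for weaker inhibition and lower numbers for stronger inhibition), compound 1 gives 17600 nM and compound 2 gives 16300 nM. These two numbers sit together: the step of a 1.1-fold lower number from compound 1 to compound 2 (0.03 log units; within the scatter) is the only one in the set, and it lies within the scatter, so compound 2 cannot be set apart from compound 1 on this assay.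

Compound 3, `CCN1CCN(c2ccc(-c3cc(=O)c4c(O)cc(O)c(Oc5c(C)n[nH]c5C)c4o3)cc2)CC1`, is the next step from compound 2. The change is hydrogen in place of methyl on a saturated chain carbon bound to an amine nitrogen in a ring and a saturated chain carbon. Among the measured compounds shown here, the only measured step that bears on it is a 1.1-fold lower number from compound 1 to compound 2 (0.03 log units; within the scatter), which altered the same amine-bearing ring portion of the molecule and produced nothing beyond the scatter. For the measured compounds named here, nothing in the measured pair suggests that trimming the chain on that ring nitrogen should shift this assay appreciably, and the data hold no larger step to argue otherwise. The expectation is therefore that the step of a 1.0-fold lower number from compound 2 to compound 3 (0.01 log units; within the scatter) stays within the scatter. Compound 3 is accordingly estimated at 16000 nM in this assay, with a range from 8000 nM to 33000 nM.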

Compound 3, half-maximal inhibitory concentration: 15500 nM
Estimate against measurement, compound 3: 1.0-fold (0.01 log units) above; low and high end bracket the measured number.
By their numbers in this assay, from the lowest: compounds 3, 2 and 1 (each within the scatter of the next).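

In this assay, the step from isopropyl to ethyl at the saturated chain carbon bound to an amine nitrogen in a ring gives a 1.1-fold lower number from compound 2 to compound 3 (0.02 log units; within the scatter). Removing this methyl, a change of a single carbon, therefore leaves the read-out within the scatter, which the earlier pair could not show because it compared two different ring groups rather than two chains on the same ring. The other new comparison, 4-ethylpiperazin-1-yl in place of 1,4-diazepan-1-yl on an aromatic carbon, gives a 1.1-fold lower number from compound 1 to compound 3 (0.06 log units; within the scatter), so the three amine-bearing groups cannot be told apart on this read-out, and no preference among them can be drawn.

On these data alone, whether a longer chain, a benzyl group or a carboxylic acid in place of the ethyl of 4-ethylpiperazin-1-yl would move the number beyond the scatter remains open. The compounds shown also offer no measured account of why these changes leave the read-out within the scatter.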